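A few compounds are considered here, and "the series" means these few. Any claim that something is new, unique, unknown or untested is made for them only; others in the source may bear on it.

Compound 1 `CN(C)c1ccc(/C=N/Nc2nc3ccccc3s2)cc1` was tested in a functional assay on MDA-MB-435 cells (Homo sapiens) for cytotoxicity, read by MTT assay, with a stated time of 72 h; on this read-out lower numbers stand for stronger inhibition and higher numbers for weaker inhibition. In that assay compound 1 reaches only the limit of the assay, > 16800 nM, so no number stands for it. Compound 2 `Fc1ccc(/C=N/Nc2nc3ccccc3s2)c(F)c1` likewise gives only a limit in this assay, > 17200 nM. Compound 1 therefore sits at a limit, as does the other value shown (the limit of > 16800 nM in this assay, at which 1 of the 2 values shown sits; (the limit of > 17200 nM in this assay, at which 1 of the 2 values shown sits)). Compound 3 `C(=N/Nc1nc2ccccc2s1)\c1ccc(-c2ccccn2)cc1` differs from compound 1 by pyridin-2-yl in place of dimethylamino on an aromatic carbon. Going by the values given here, no step between measured compounds bears on this change, so the expected step of an at least 1.1-fold lower number from compound 1 to compound 3 (0.04 log units; that floor lies within the scatter) rests on no measured evidence and is guessed as small. Compound 3 is expected to give about 15000 nM, between 3000 nM and 50000 nM, and may again end at a limit.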

Compound 3, half-maximal inhibitory concentration: > 15100 nM
Compound 3: no number, only a limit (the forecaster's own chance of this, stated with the estimate: 60%); middle value at least 1.0-fold (0.00 log units) away from the limit.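

In this assay compound 3 gives only the limit > 15100 nM and no number. Going by these compounds alone, compound 1 also stands at a limit, so no step between compound 1 and compound 3 can be read. The compounds shown leave open whether pyridin-2-yl in place of dimethylamino changes the result in this assay at all.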